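The compounds below may be only part of what the source reports. "The series", "measured", "known", "first", "only" and "open" are said of these compounds alone.

Measured in an in vitro ADME assay on microsomes from liver (Homo sapiens) for metabolic stability, tested at 1 uM; a higher number here means that the compound lasts longer, a lower number that the compound disappears faster:
- Compound 1 `CC(C)[C@]1(C(=O)N2C[C@@H]3C[C@H]2CN3C(=O)OC(C)(C)C)CC[C@@H](NC2CCOCC2)C1`: > 2 h
- Compound 2 `CC(C)C(=O)N1C[C@@H]2C[C@H]1CN2C(=O)[C@@]1(C(C)C)CC[C@@H](NC2CCOCC2)C1`: > 2 h

Each of these entries is a limit of the assay and not a number. Compound 2 therefore has no exact position on the scale: in this assay it stands at > 2 h, which is a limit. It shares that position with compound 1, as the limit of > 2 h in this assay, at which 2 of the 2 values shown sit, shows.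

Compound 3 `CC(C)[C@]1(C(=O)N2C[C@@H]3C[C@H]2CN3C(=O)C(C)(C)C)CC[C@@H](NC2CCOCC2)C1` differs from compound 2 in one place: methyl in place of hydrogen on a saturated chain carbon bound to a carbonyl carbon and two saturated chain carbons. This is methyl in place of hydrogen on a saturated chain carbon bound to a carbonyl carbon and two saturated chain carbons, so that isopropylcarbonyl becomes (tert-butyl)carbonyl.

Among the compounds with values here, the only measured step that bears on this change is a step that the two limits leave unreadable from compound 1 to compound 2. It gives no size to carry over and no direction, so no step beyond the usual scatter is expected in this assay. Compound 3 will most likely also be reported as a limit. The step that the estimate implies is expected to be a step that the limit leaves unreadable from compound 2 to compound 3. For compound 3 the half-life is estimated at 3 h, with an expected range of 1.5 h to 6 h.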

Compound 3, half-life: > 2 h
Compound 3 ended at the assay's limit; the forecaster's own chance of this, stated with the estimate: 75%; the middle value is on the limit's open side.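

In this assay compound 3 gives > 2 h, which is a limit and not a number. Within the data shown here, no step among compound 1, compound 2 and compound 3 can therefore be read. The compounds shown leave open the actual half-life of each and whether isopropyl, tert-butyl and tert-butoxy on the carbonyl carbon differ at all, since all three share one position: the limit of > 2 h in this assay, at which 3 of the 3 values shown sit.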